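This account rests on a few compounds, and the source may have more. Where it says the series, first, only, none or still open, it means among the compounds named here.

Compound 3 `Cc1ccccc1NC(=O)Nc1ccc(C(=O)N[C@H](CCCCNC(=O)/C=C/c2cccnc2)C(=O)N[C@H](CCCC(=O)O)C(=O)NC2(C(N)=O)CCCCC2)cc1` is the reference point of the series. Going by the values given here, in an assay on MOLT-4 cells for inhibition of integrin alpha-4/beta-1 (Homo sapiens) (a higher number here means a weaker inhibitor, a lower number a stronger inhibitor), compound 3 gives 0.0372 nM, the lowest of the three numbers so far; compound 2 `NC(=O)C1(NC(=O)[C@@H](CCCC(=O)O)NC(=O)[C@@H](CCCCNC(=O)/C=C/c2cccnc2)NC(=O)c2cccc(Nc3nc4ccccc4[nH]3)c2)CCCCC1` gives 186 nM and compound 1 `NC(=O)C1(NC(=O)[C@@H](CCCC(=O)O)NC(=O)[C@@H](CCCCNC(=O)/C=C/c2cccnc2)NC(=O)c2ccc(Nc3nc4ccccc4[nH]3)cc2)CCCCC1` gives 420 nM, both far above it. Compound 4 `Cc1cccc2[nH]c(Nc3ccc(C(=O)N[C@H](CCCCNC(=O)/C=C/c4cccnc4)C(=O)N[C@H](CCCC(=O)O)C(=O)NC4(C(N)=O)CCCCC4)cc3)nc12` is not yet measured; it differs from compound 3 by 4-methyl-1H-benzimidazol-2-yl in place of (2-methylphenyl)carbamoyl on a nitrogen on an aromatic ring. Among the compounds with values here, the one measured step that bears on this change is an 11000-fold lower number from compound 1 to compound 3 (4.05 log units; beyond the scatter); compound 4 reverses that exchange, and its 4-methyl-1H-benzimidazol-2-yl carries a methyl that the benzimidazol-2-yl of compound 1 lacks. Within the data shown here, no measured pair shows what that methyl does. The expected step is a 5400-fold higher number from compound 3 to compound 4 (3.73 log units; beyond the scatter), back toward the number of compound 1. For compound 4 in this assay the estimate is 200 nM, within 30 nM to 1500 nM.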

Compound 4, half-maximal inhibitory concentration: 27.5 nM
Compound 4: middle estimate off by 7.3-fold (0.86 log units), on the high side; the whole stated range lies above it.
By their numbers in this assay, from the lowest: compound 3; then compound 4; then compound 2; then compound 1.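

In this assay, methyl in place of hydrogen on an aromatic carbon of the benzimidazol-2-yl group gives a 15-fold lower number from compound 1 to compound 4 (1.18 log units; beyond the scatter), so this small change recovers part of the potency gap left by that group. The (2-methylphenyl)carbamoyl group still keeps a large lead over 4-methyl-1H-benzimidazol-2-yl, with a 740-fold higher number from compound 3 to compound 4 (2.87 log units; beyond the scatter), although the two groups match in heavy-atom, donor and acceptor counts. No evidence available here explains either step.

Open, going by these compounds, is whether a chlorine or a methoxy group on the same aromatic carbon would match the methyl. Also open, on these data alone, is what phenylcarbamoyl, lacking the methyl, would give against compound 3.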